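Changing the benzothiazole substituent on compound 2

The compounds below may be only part of what the source reports. "The series", "measured", "known", "first", "only" and "open" are said of these compounds alone.

In a functional assay on MCF7 cells (Homo sapiens) for cytotoxicity, read by MTT assay, with a stated time of 48 h (a higher number here means a weaker inhibitor, a lower number a stronger inhibitor), compound 2 `COc1ccc2nc(NC(=O)c3cc(-c4cc(OC)c(OC)c(OC)c4)n4nc(-c5ccccc5)cc4n3)sc2c1` gives 2950 nM, the lowest of the two numbers recorded so far. Its nearest neighbour, compound 1 `COc1ccc2nc(NC(=O)c3cc(-c4ccc(F)cc4)n4nc(-c5ccccc5)cc4n3)sc2c1`, gives 24500 nM in this assay. Among the compounds with values here, the single measured step, an 8.3-fold lower number from compound 1 to compound 2 (0.92 log units; beyond the scatter), concerns the aryl group attached to the shared core and leaves the amide-type nitrogen untouched.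

Compound 3 `COc1cc(-c2cc(C(=O)Nc3nc4cc(C)c(C)cc4s3)nc3cc(-c4ccccc4)nn23)cc(OC)c1OC` has not yet been measured in this assay. It differs from compound 2 in one place: 5,6-dimethyl-1,3-benzothiazol-2-yl in place of 6-methoxy-1,3-benzothiazol-2-yl on an amide-type nitrogen. Within the data shown here, no measured step bears on this position, so the data give no direction for the swap. Because an 8.3-fold lower number from compound 1 to compound 2 (0.92 log units; beyond the scatter) acted elsewhere on the molecule, it offers no guide to the size of a change at the amide-type nitrogen. The substituents exchanged are of similar size, and the expectation is therefore a step that stays within the scatter.

Compound 3 is expected to show a 1.2-fold higher number from compound 2 to compound 3 (0.07 log units; within the scatter). In this assay compound 3 is estimated at 3500 nM, with a range from 1000 nM to 12000 nM.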

Compound 3, half-maximal inhibitory concentration: 2290 nM
Compound 3: middle estimate off by 1.5-fold (0.18 log units), on the high side; the range from low to high includes it.
By their numbers in this assay, from the lowest: compounds 3 and 2 (each within the scatter of the next); then compound 1.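

In this assay, the first step measured at the amide-type nitrogen is a 1.3-fold lower number from compound 2 to compound 3 (0.11 log units; within the scatter), so compound 2 and compound 3 cannot be told apart. The result shows that, with the 3,4,5-trimethoxyphenyl group in place, 5,6-dimethyl-1,3-benzothiazol-2-yl can take the place of 6-methoxy-1,3-benzothiazol-2-yl without a change beyond the scatter, even though the group that leaves has an oxygen and 3 hydrogen-bond acceptors and the group that enters has no oxygen and 2. No experimental evidence is available to explain this result.

On these data alone, this pair tests only two substituted 1,3-benzothiazol-2-yl groups of equal heavy-atom count, so it remains open whether a larger departure at the amide-type nitrogen, such as a benzothiazole carrying an amine, a carboxylic acid or a longer alkoxy chain, would also leave the number within the scatter. As far as these compounds go, it also remains open whether the same exchange would behave alike on the 4-fluorophenyl compound 1, where the aryl group differs by an 8.3-fold lower number from compound 1 to compound 2 (0.92 log units; beyond the scatter).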